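Removing Bromine: One Change Made Twice

This account rests on a few compounds, and the source may have more. Where it says the series, first, only, none or still open, it means among the compounds named here.

Of the compounds shown here, three share a core and have been measured in a functional assay on HepG2 cells (Homo sapiens) for inhibition, read by MTT assay, with a stated time of 48 h; a higher number here means a weaker inhibitor, a lower number a stronger inhibitor. Compound 1 `Brc1cccc(CSc2nnc(-c3ccncc3)n2-c2ccccc2)c1` gives 7040 nM. Compound 2 `c1ccc(CSc2nnc(-c3ccncc3)n2-c2ccccc2)cc1` gives 12900 nM. The two differ in one place, (hydrogen in place of bromo on an aromatic carbon), and the step of a 1.8-fold higher number from compound 1 to compound 2 (0.26 log units; within the scatter) shows that, within this series, taking the bromo away on this side chain changes the number only a little.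

Compound 3 `O=C(CSc1nnc(-c2ccncc2)n1-c1ccccc1)N/N=C/c1cc(Br)ccc1O` carries a different side chain on the shared core; how its core differs from that of compound 1 is not broken down here. In this assay compound 3 gives 4390 nM, which is a lower number than compound 2 gives, while its gap to compound 1 lies within the scatter, so no order between compound 3 and compound 1 can be claimed.

Compound 4 `O=C(CSc1nnc(-c2ccncc2)n1-c1ccccc1)N/N=C/c1ccccc1O` is not yet measured. It differs from compound 3 by hydrogen in place of bromo on an aromatic carbon. This is the same kind of change as that from compound 1 to compound 2, though not the same: in compound 3 the bromo sits meta to a large group and also para to a hydroxy group, whereas in compound 1 it sits meta to a large group only. Starting from the value of compound 3, the step of a 1.7-fold higher number from compound 3 to compound 4 (0.23 log units; within the scatter) is expected, of about the size seen in the step from compound 1 to compound 2, because that step a 1.8-fold higher number from compound 1 to compound 2 (0.26 log units; within the scatter) is the only measured example of this change. Compound 4 is therefore estimated at 7500 nM, plausibly between 3500 nM and 16000 nM.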

Compound 4, half-maximal inhibitory concentration: 11300 nM
Compound 4: the middle estimate sits 1.5-fold (0.18 log units) below what was measured, within the range that was stated.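

In this assay, putting hydrogen in place of bromo, which turns the 5-bromo-2-hydroxyphenyl group into 2-hydroxyphenyl, gives a 2.6-fold higher number from compound 3 to compound 4 (0.41 log units; beyond the scatter), so compound 3 is the stronger inhibitor of this pair. Set side by side, the steps made by this one change on the two cores cannot be told apart, so as far as these two pairs can show, the size of the step carries over from one core to the other: the same change on two cores in this assay, a 1.8-fold higher number (0.26 log units; within the scatter) from compound 1 to compound 2 and a 2.6-fold higher number (0.41 log units; beyond the scatter) from compound 3 to compound 4, 1.4-fold (0.15 log units) apart, within the scatter of two such steps This does not show a general rule for the series, since it rests on only two pairs, only the step on the side chain of compound 3 stands clear of the scatter, and nothing here explains why bromo and hydrogen differ on that side chain.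

The compounds shown leave open whether a different atom or group in the place of bromo, such as chloro, methoxy or an amine, would give a number like that of compound 3 or like that of compound 4. They also leave open how much the hydroxy group contributes, which only a pair differing at that one place could show.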